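Trifluoromethyl in place of methyl: working notes

This account rests on a few compounds, and the source may have more. Where it says the series, first, only, none or still open, it means among the compounds named here.

Measured so far:
compound 1 `Cc1ccc(N2CCCC2)c(C(=O)Nc2ccc(CNC(=O)OCc3cccnc3)cc2)c1`: 1650 nM
compound 2 `Cc1cccc(C(=O)Nc2ccc(CNC(=O)OCc3cccnc3)cc2)c1N1CCCC1`: 1030 nM

In a functional assay on HGC-27 cells (Homo sapiens) for inhibition, read by MTT assay, with a stated time of 72 h (a lower number here means a stronger inhibitor, a higher number a weaker inhibitor), compound 1 gives 1650 nM, and compound 2 gives 1030 nM. Going by the values given here, compound 1 therefore stands level with the only other measured compound: the two values lie within the scatter of each other, and neither compound can be ranked over the other.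

The next compound to be tested is compound 3 `O=C(NCc1ccc(NC(=O)c2cc(C(F)(F)F)ccc2N2CCCC2)cc1)OCc1cccnc1`. Compared with compound 1, it has trifluoromethyl in place of methyl on an aromatic carbon, on a six-membered aromatic ring of carbon only, meta to a large group and para to a pyrrolidin-1-yl group: trifluoromethyl in place of methyl on an aromatic carbon.

Among the compounds with values here, the series holds no measured step for this exchange, or for any other single change, so the data do not show how much this position matters. With nothing to set a direction, no change beyond the scatter is expected in this assay. The expected step is a 1.2-fold lower number from compound 1 to compound 3 (0.07 log units; within the scatter), and this estimate carries wide uncertainty. For compound 3 the estimated value is 1400 nM, with an expected range from 500 nM to 3500 nM.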

Compound 3, half-maximal inhibitory concentration: 790 nM
Beside the measured number, compound 3's estimate is 1.8-fold (0.25 log units) above it, and the stated range covers the measured number.
By their numbers in this assay, from the lowest: compounds 3, 2 and 1 (each within the scatter of the next, the first and the last beyond it).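

In this assay, going by these compounds alone, the exchange of methyl for trifluoromethyl gives a 2.1-fold lower number from compound 1 to compound 3 (0.32 log units; beyond the scatter), the first single change with a measured size beyond the scatter. It shows that the substituent on this aromatic carbon, para to the pyrrolidin-1-yl group and meta to a large group, does affect the read-out, and that the position accepts trifluoromethyl, the larger group by heavy-atom count, with no loss of inhibition; the step is modest and rests on one pair of compounds. Nothing measured on these compounds bears on why the number moves in this direction.

The compounds shown leave open whether the step belongs to trifluoromethyl itself or would also appear with another group on the same carbon, such as chlorine, a nitrile or a methoxy group, or with hydrogen in place of methyl. They also leave open whether the same exchange on the methyl of compound 2 would move the number in the same direction and by a similar size.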